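Swapping bromo for chloro on a sulfur-containing core

This account rests on a few compounds, and the source may have more. Where it says the series, first, only, none or still open, it means among the compounds named here.

Measured compounds in a functional assay on A549 cells (Homo sapiens) for antiproliferative activity, read by MTT assay, with a stated time of 72 h; a lower number here means a stronger inhibitor, a higher number a weaker inhibitor:
- compound 1, `NC1=NC2(CCOCC2)N(OCCCOc2ccccc2Cl)C(N)=N1`, gives 2700 nM
- compound 2, `NC1=NC2(CCOCC2)N(OCCCOc2ccccc2Br)C(N)=N1`, gives 160 nM
- compound 3, `NC1=NC2(CCSCC2)N(OCCCOc2ccccc2Br)C(N)=N1`, gives 40 nM

Compound 3 has the lowest number of the three. How its core differs from that of compound 2 is not broken down here. Compound 4, `NC1=NC2(CCSCC2)N(OCCCOc2ccccc2Cl)C(N)=N1`, is not yet measured; it differs from compound 3 by chloro in place of bromo on an aromatic carbon. The same change turns compound 2 into compound 1, (chloro in place of bromo on an aromatic carbon), and there it gave a 17-fold higher number from compound 2 to compound 1 (1.23 log units; beyond the scatter). Because that step a 17-fold higher number from compound 2 to compound 1 (1.23 log units; beyond the scatter) was large, a step of similar direction and size is expected for compound 4, namely a 14-fold higher number from compound 3 to compound 4 (1.14 log units; beyond the scatter), though it rests on a single earlier pair. Compound 4 is therefore estimated at 550 nM in this assay, expected to lie between 150 nM and 2000 nM.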

Compound 4, half-maximal inhibitory concentration: 80 nM
Compound 4: middle estimate off by 6.9-fold (0.84 log units), on the high side, outside the stated range (below it).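

In this assay, on the sulfur-containing core, chloro in place of bromo gives a 2.0-fold higher number from compound 3 to compound 4 (0.30 log units; within the scatter) and so the two values cannot be told apart. The same swap does not have the same size on the two cores: the same change on two cores in this assay, a 17-fold higher number (1.23 log units; beyond the scatter) from compound 2 to compound 1 and a 2.0-fold higher number (0.30 log units; within the scatter) from compound 3 to compound 4, 8.4-fold (0.93 log units) apart, beyond the scatter of two such steps. This shows that the step seen on one core could not simply be carried over to the other, but two pairs do not show why the steps differ or what the swap would do on a further core.

The compounds shown leave open what a fluoro, iodo or methyl group on the same aromatic carbon would give on either core. They also leave open how a longer chain would fare in place of the propyl chain joining the core to the aromatic ring.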